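Nitro in Place of Bromo at the Assay Limit

This account rests on a few compounds, and the source may have more. Where it says the series, first, only, none or still open, it means among the compounds named here.

Compound 3 `CCC(COc1cccc(Br)c1)OC(=O)NCc1ccccc1` carries a bromo group on the aromatic ring of the shared core. In an assay for inhibition of zeta-carotene desaturase, chloroplastic/chromoplastic (Capsicum annuum), using a Dixon plot, with a stated time of 8 h (on this read-out higher numbers stand for weaker inhibition and lower numbers for stronger inhibition), compound 3 gives > 100000 nM, which is a limit of the assay and not a number. Compound 1 `CCC(COc1cccc(Cl)c1)OC(=O)NCc1ccccc1` gives > 100000 nM in this assay, again a limit. Compound 2 `CCC(COc1cccc(F)c1)OC(=O)NCc1ccccc1` gives > 100000 nM in this assay, also a limit. Because all three values sit at the limit of > 100000 nM in this assay, at which 3 of the 3 values shown sit, the steps a step that the two limits leave unreadable from compound 1 to compound 2, a step that the two limits leave unreadable from compound 1 to compound 3 and a step that the two limits leave unreadable from compound 2 to compound 3 cannot be read for size or direction. Compound 4 `CCC(COc1cccc([N+](=O)[O-])c1)OC(=O)NCc1ccccc1` carries the change (nitro in place of bromo on an aromatic carbon). Among the measured compounds shown here, no measured step covers a swap of a halogen for a nitro group, and the halogen steps themselves are unreadable, so nothing in this assay points to a gain or a loss. The step of a number no higher from compound 3 to compound 4 (the limit leaves the size open) is therefore expected to leave the read-out where the measured compounds sit. Compound 4 is estimated at 100000 nM, with a range from 30000 nM to 300000 nM, most likely reported only as a limit.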

Compound 4, half-maximal inhibitory concentration: > 100000 nM
Compound 4: a limit, no number; the forecaster's own chance of this, stated with the estimate: 85%; the middle value sits exactly at the limit.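

In this assay compound 4 gives > 100000 nM, which is a limit of the assay and not a number. Its steps from compound 1, compound 2 and compound 3 therefore cannot be read for size or direction: the limit of > 100000 nM in this assay, at which 4 of the 4 values shown sit.

The compounds shown leave open whether the chloro, fluoro, bromo and nitro compounds differ at all on this read-out.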